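This account rests on a few compounds, and the source may have more. Where it says the series, first, only, none or still open, it means among the compounds named here.

Measured compounds:

- Compound 1, `C=CCn1c(=O)/c(=C\c2ccc(Cl)c(Cl)c2)[nH]c(=O)/c1=C\c1ccccc1`: in a functional assay on BGC-823 cells (Homo sapiens) for cytotoxicity, read by CCK-8 assay, with a stated time of 72 h (on this read-out higher numbers stand for weaker inhibition and lower numbers for stronger inhibition), compound 1 gives "not active" (no number reported)
- Compound 2, `C=CCn1c(=O)/c(=C\c2cc(F)ccc2C)[nH]c(=O)/c1=C\c1ccccc1OC`: in this assay compound 2 gives 1600 nM
- Compound 3, `C=CCn1c(=O)/c(=C\c2cc(OC)c(OC)c(OC)c2)[nH]c(=O)/c1=C\c1cccc(Br)c1`: in this assay compound 3 gives "not active" (no number reported)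

Among the compounds with values here, only compound 2 is described by a number in this assay; compound 1 and compound 3 are described only as not active, so no numbered comparison can be drawn among the three, and no step between them can be sized.

Compound 4, `C=CCn1c(=O)/c(=C\c2cccc(Cl)c2Cl)[nH]c(=O)/c1=C\c1ccccc1OC`, shares the core of compound 2 and differs from it in a single place: 2,3-dichlorophenyl in place of 5-fluoro-2-methylphenyl on a double-bonded chain carbon bound to an aromatic carbon. Compound 1 also carries two chlorines on that side of the core and is reported as not active, though its other arm differs as well, so it cannot settle the question on its own.

Within the data shown here, with no measured step of this kind to lean on, the expectation is worded cautiously. Compound 4 is expected to lose a small amount of potency in this assay, a step of a 1.9-fold higher number from compound 2 to compound 4 (0.27 log units; within the scatter) that may well stay within the usual scatter. The estimated value for compound 4 is 3000 nM, with a likely range from 1000 nM to 10000 nM.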

Compound 4, half-maximal inhibitory concentration: 2200 nM
Compound 4: middle estimate off by 1.4-fold (0.13 log units), on the high side; the range from low to high includes it.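

In this assay, within the data shown here, the exchange of 5-fluoro-2-methylphenyl for 2,3-dichlorophenyl on a double-bonded chain carbon bound to an aromatic carbon gives a 1.4-fold higher number from compound 2 to compound 4 (0.14 log units; within the scatter) and provides the first sized step at this place. The two compounds cannot be told apart, so with the rest of the molecule unchanged, the fluorine and methyl pair is not required for a numbered result, and two chlorines on this ring do not by themselves lead to a "not active" report. Nothing measured here explains why the exchange makes so little difference.

On these data alone, both rings carry only halogen or methyl groups, so it remains open whether an amine or a carboxylic acid on this ring would keep a numbered result. A longer chain in place of the allyl group on the core is also an open question.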